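The source may report more compounds than this note shows. Statements on the series, on what has been measured and on what is new or still open speak of the compounds shown alone.

Working notes on the amide series. In an assay on HL-60 cells for agonist activity at vitamin D3 receptor (Homo sapiens), read by microscopy, with a stated time of 96 h (a lower number here means that less compound is needed, a higher number that more compound is needed for the effect), compound 2 `C#CCNC(=O)c1ccc(C(CC)(CC)c2ccc(OCC(=O)C(C)(C)C)c(C)c2)n1CC` gives 2200 nM, the highest number of the three measured; compound 1 `CC[C@@H](C)[C@H](NC(=O)c1ccc(C(CC)(CC)c2ccc(OCC(=O)C(C)(C)C)c(C)c2)n1CC)C(=O)OC` gives 590 nM, and compound 3 `CCn1c(C(=O)NCCN)ccc1C(CC)(CC)c1ccc(OCC(=O)C(C)(C)C)c(C)c1` gives 120 nM. The steps on record all vary the amide substituent: a 3.7-fold higher number from compound 1 to compound 2 (0.57 log units; beyond the scatter), an 18-fold lower number from compound 2 to compound 3 (1.26 log units; beyond the scatter), and a 4.9-fold lower number from compound 1 to compound 3 (0.69 log units; beyond the scatter). Compound 4 `CCn1c(C(=O)N(C)c2ccccc2)ccc1C(CC)(CC)c1ccc(OCC(=O)C(C)(C)C)c(C)c1` carries methyl(phenyl)amino in place of propargylamino on a carbonyl carbon. Going by the values given here, no measured step adds an aromatic ring here or removes the amide hydrogen, so the bearing of the earlier steps is indirect; the closest analogy is that a larger substituent in compound 1 gave a lower number than compound 2. In this assay compound 1 stands at 590 nM. A modest lowering is therefore expected, a 2.4-fold lower number from compound 2 to compound 4 (0.39 log units; beyond the scatter), and compound 4 is estimated at 900 nM with a range of 300 nM to 3000 nM in this assay.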

Compound 4, half-maximal effective concentration: 18500 nM
Beside the measured number, compound 4's estimate is 21-fold (1.31 log units) below it, and the stated range ends below it.
By their numbers in this assay, from the lowest: compound 3; then compound 1; then compound 2; then compound 4.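

In this assay methyl(phenyl)amino on the carbonyl carbon gives the highest number of the four (an 8.4-fold higher number from compound 2 to compound 4 (0.92 log units; beyond the scatter); a 31-fold higher number from compound 1 to compound 4 (1.50 log units; beyond the scatter); a 150-fold higher number from compound 3 to compound 4 (2.19 log units; beyond the scatter)). A larger group here therefore does not by itself lower the number: compound 1 lies under compound 2 and compound 4 lies over it, and the hydrogen-bond donor count also falls from 1 to 0 in this change. No evidence on record accounts for this rise. Open, as far as these compounds go, is whether the phenyl ring or the methyl on the nitrogen carries the step; phenylamino and methyl(propargyl)amino would separate the two.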